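A few compounds are considered here, and "the series" means these few. Any claim that something is new, unique, unknown or untested is made for them only; others in the source may bear on it.

Measured in a functional assay on MGC-803 cells (Homo sapiens) for inhibition, read by CCK-8 assay, with a stated time of 48 h; on this read-out lower numbers stand for stronger inhibition and higher numbers for weaker inhibition:

- compound 1 `COc1ccc(CN(C(=O)CSC(=S)N2CCN(C)CC2)c2cc(OC)c(OC)c(OC)c2)cc1`: 1280 nM
- compound 2 `COc1ccc(CN(C(=O)CSC(=S)N2CCN(Cc3ccc(C(C)(C)C)cc3)CC2)c2cc(OC)c(OC)c(OC)c2)cc1`: 5390 nM
- compound 3 `COc1ccc(CN(C(=O)CSC(=S)N2CCCC2)c2cc(OC)c(OC)c(OC)c2)cc1`: > 20000 nM

Compound 1 has the lowest number of the series at 1280 nM, and both steps away from it lead to higher numbers. For compound 3, the reading of > 20000 nM is a limit of the assay and not a number.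

Compound 4 `COc1ccc(CN(C(=O)CSC(=S)N2CCc3ccccc32)c2cc(OC)c(OC)c(OC)c2)cc1` has not yet been measured. Its change from compound 1 is 2,3-dihydro-1H-indol-1-yl in place of 4-methylpiperazin-1-yl on a thiocarbonyl carbon.

The closest guide is the swap at this same place, which gives an at least 15-fold higher number from compound 1 to compound 3 (1.19 log units; beyond the scatter), a large step. The other measured step, a 4.2-fold higher number from compound 1 to compound 2 (0.62 log units; beyond the scatter), is modest and adds 4-(tert-butyl)phenyl while keeping the ring that compound 4 loses. With only these two steps to go on, a move to a higher number in this assay is expected, of modest to large size.

The estimated change is a 5.5-fold higher number from compound 1 to compound 4 (0.74 log units; beyond the scatter). For compound 4, the expected value is 7000 nM, with an estimated range from 1500 nM to 20000 nM.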

Compound 4, half-maximal inhibitory concentration: 8410 nM
Compound 4: middle estimate off by 1.2-fold (0.08 log units), on the low side; low and high end bracket the measured number.
By their numbers in this assay, from the lowest: compound 1; then compounds 2 and 4 (each within the scatter of the next). At a limit, above all of these: compound 3.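

In this assay, 2,3-dihydro-1H-indol-1-yl on the thiocarbonyl carbon gives a 6.6-fold higher number from compound 1 to compound 4 (0.82 log units; beyond the scatter), so this position accepts a group other than 4-methylpiperazin-1-yl without the reading reaching the limit, although compound 1 keeps the lowest number. Set against the pyrrolidin-1-yl group, the same group gives an at least 2.3-fold lower number from compound 3 to compound 4 (0.37 log units; beyond the scatter), which shows that the two replacements at this position are not equivalent. The reading for compound 3 is a limit and not a number, so this second step gives only a minimum size: the limit of > 20000 nM in this assay, at which 1 of the 4 values shown sits.

On these data alone, it remains open whether compound 1 owes its lower number to the methyl-bearing ring nitrogen, which a morpholine or piperidine ring at this place would probe. As far as these compounds go, it is also open whether the aromatic ring of compound 4 matters, which a 4-phenylpiperazin-1-yl group could help to test.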